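The compounds below may be only part of what the source reports. "The series", "measured", "known", "first", "only" and "open" are said of these compounds alone.

Compound 1 `COc1nc(CC(O)(COC(C)=O)COC(C)=O)c(C)c(OC)n1` is the starting point. In a functional assay on MCF7 cells (Homo sapiens) for antiproliferative activity, read by MTT assay, with a stated time of 72 h (on this read-out higher numbers stand for weaker inhibition and lower numbers for stronger inhibition), compound 1 gives > 100000 nM, which is a limit of the assay rather than a number. Compound 2 `COc1nc(CC(F)(COC(C)=O)COC(C)=O)c(C)c(OC)n1` differs from it in one place: fluoro in place of hydroxy on a saturated chain carbon bound to three saturated chain carbons. Compound 2 also gives only a limit, > 100000 nM. The step that the two limits leave unreadable from compound 1 to compound 2 is therefore unreadable, because both values sit at the limit of > 100000 nM in this assay, at which 3 of the 3 values shown sit. Compound 3 `CC(=O)OCC(O)(COC(C)=O)Cc1c(C)c(=O)[nH]c(=O)n1C` has another core; the difference between the two cores is not broken down here. Compound 3 gives > 100000 nM, again a limit. Compound 4 `CC(=O)OCC(F)(COC(C)=O)Cc1c(C)c(=O)[nH]c(=O)n1C` repeats the same change on compound 3: fluoro in place of hydroxy on a saturated chain carbon bound to three saturated chain carbons. Since the earlier step could not be read, the step of a number no higher from compound 3 to compound 4 (the limit leaves the size open) is expected to be small. Compound 4 is expected to come out near 100000 nM, most probably as a limit once more.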

Compound 4, half-maximal inhibitory concentration: > 100000 nM
Compound 4: no number, only a limit; the forecaster's own chance of this, stated with the estimate: 85%; the middle value sits exactly at the limit.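

No size can be read for the step between compound 3 and compound 4, because both values are limits rather than numbers: the limit of > 100000 nM in this assay, at which 4 of the 4 values shown sit. The compounds shown leave open whether fluoro in place of hydroxy changes activity on either core.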